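The source may hold more compounds than are shown below. What is called first, only, known or untested is meant among the compounds shown, and "the series" means these compounds.

Compound 1 `COc1ccc(CN(C(=O)CSC(=S)N2CCN(C(=O)OC(C)(C)C)CC2)c2cc(OC)c(OC)c(OC)c2)cc1F`: 8210 nM
Compound 2 `COc1ccc(CN(C(=O)CSC(=S)N2CCN(C(=O)OC(C)(C)C)CC2)c2cc(OC)c(OC)c(OC)c2)cc1[N+](=O)[O-]`: 980 nM

Among the measured compounds shown here, in a functional assay on HCT-116 cells (Homo sapiens) for inhibition, read by CCK-8 assay, with a stated time of 48 h (on this read-out lower numbers stand for stronger inhibition and higher numbers for weaker inhibition), compound 2 gives 980 nM, the lower of the two numbers so far. Compound 3 `COc1ccc(CN(C(=O)CSC(=S)N2CCN(C(=O)OC(C)(C)C)CC2)c2cc(OC)c(OC)c(OC)c2)cc1O` has hydroxy in place of nitro on an aromatic carbon, ortho to a methoxy group (hydroxy in place of nitro on an aromatic carbon). For the measured compounds named here, only one measured step bears on this change: an 8.4-fold lower number from compound 1 to compound 2 (0.92 log units; beyond the scatter), with nitro in place of fluoro on that same carbon. On these data alone, this single step shows that a swap here can matter, but hydroxy is untested, so no direction follows. The expected change is therefore small but uncertain, a 1.2-fold lower number from compound 2 to compound 3 (0.09 log units; within the scatter). For compound 3 the estimated value is 800 nM, with an expected range of 120 nM to 5000 nM.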

Compound 3, half-maximal inhibitory concentration: 128 nM
Estimate against measurement, compound 3: 6.3-fold (0.80 log units) above; measured number inside the range.
By their numbers in this assay, from the lowest: compound 3; then compound 2; then compound 1.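

Placing hydroxy on this aromatic carbon in this assay gives a 7.7-fold lower number from compound 2 to compound 3 (0.88 log units; beyond the scatter) and, against fluoro, a 64-fold lower number from compound 1 to compound 3 (1.81 log units; beyond the scatter) in the same assay. The position, ortho to a methoxy group, therefore tolerates more than a single favourable swap, and among these three groups the only one with a hydrogen-bond donor gives the lowest number. No measurement at hand explains why this group stands out.

On these data alone, whether an amine or a carboxylic acid on this carbon would match hydroxy remains open. So does whether the same gain would hold with other changes to the shared core.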